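The source may report more compounds than this note shows. Statements on the series, on what has been measured and on what is new or still open speak of the compounds shown alone.

Working notes on the series. Of the compounds shown here, two on the shared core have been measured in a functional assay (aorta) with Rattus norvegicus as the target; on this read-out lower numbers stand for stronger inhibition and higher numbers for weaker inhibition. Among the compounds with values here, compound 1 `CC1(C)Oc2ccc(C#N)cc2[C@@H](/N=C(\NC#N)NCc2ccccc2)[C@@H]1O` gives 2400 nM in this assay, which is the higher of the two numbers so far. Compound 2 `CC1(C)Oc2ccc(C#N)cc2[C@@H](NC(=O)Nc2cccnc2)[C@@H]1O` gives 500 nM in this assay, a lower number than that of compound 1 and a gap that lies beyond the scatter of repeated measurements. Within the data shown here, no pair of measured compounds differs in one place only, so no single change has been isolated yet.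

Compound 3 `COC(=O)c1cccc(N/C(=N/[C@@H]2c3cc(C#N)ccc3OC(C)(C)[C@H]2O)NC#N)c1` is the next compound and has not been measured. Relative to compound 1 it differs in one place: 3-(methoxycarbonyl)phenyl in place of benzyl on an amine nitrogen. Among the measured compounds shown here, nothing measured so far isolates this exchange, so any expectation rests on compound 1 at 2400 nM and on the spread of the two numbers in this assay. For compound 3 a modest step toward lower numbers is expected, a 2.4-fold lower number from compound 1 to compound 3 (0.38 log units; beyond the scatter), close to the edge of the usual scatter. Compound 3 is therefore estimated at 1000 nM in this assay, with a range from 300 nM to 4000 nM.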

Compound 3, half-maximal inhibitory concentration: 4100 nM
Compound 3: middle estimate off by 4.1-fold (0.61 log units), on the low side, outside the stated range (above it).
By their numbers in this assay, from the lowest: compound 2; then compounds 1 and 3 (each within the scatter of the next).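

In this assay, within the data shown here, the exchange of benzyl for 3-(methoxycarbonyl)phenyl on an amine nitrogen whose other neighbour is a carbon with a double bond to nitrogen gives a 1.7-fold higher number from compound 1 to compound 3 (0.23 log units; within the scatter) and is the first single change isolated on the shared core. The step does not separate the two compounds, so at this position a benzyl group and a larger aromatic group carrying a methyl ester give readings that cannot be told apart, although the entering group brings more heavy atoms and adds hydrogen-bond acceptors. Nothing at hand accounts for this outcome.

The exchange alters two things at once, the link between nitrogen and ring and the ester on the ring, so the contribution of each stays unresolved, and the flat result may hide opposing contributions or none at all. Going by these compounds, whether a plain phenyl group, a carboxylic acid in place of the methyl ester, or a longer chain between the nitrogen and the ring would move the number beyond the scatter remains open.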